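This account rests on a few compounds, and the source may have more. Where it says the series, first, only, none or still open, it means among the compounds named here.

Measured so far in a physicochemical assay for acid dissociation, for three compounds with a shared core
Compound 1 `Cc1cc(C)cc(Cc2ccc3c(NCCCNCc4ccco4)ccnc3c2)c1` gives 9.47
Compound 2 `COc1cccc(Oc2ccc3c(NCCCNCc4ccco4)ccnc3c2)c1` gives 9.28
Compound 3 `Fc1ccc(Oc2ccc3c(NCCCNCc4ccco4)ccnc3c2)cc1` gives 9.28

Compound 3 stands level with compound 2 at the digits shown, and all three numbers lie within the usual scatter of one another. The next compound, compound 4 `c1ccc(Cc2ccc3c(NCCCNCc4ccco4)ccnc3c2)cc1`, has not yet been measured. It carries benzyl in place of 4-fluorophenoxy on an aromatic carbon on the same core.

The closest guide is compound 1, which also carries a benzyl, though a substituted one. The measured step of a number 0.19 log units lower from compound 1 to compound 3 (within the scatter) runs opposite to the new change. The step of a number 0.19 log units lower from compound 1 to compound 2 (within the scatter) has the same size, and no change at the digits printed from compound 2 to compound 3 (within the scatter) shows no difference between the two phenoxy compounds. A small upward step that stays inside the scatter is therefore expected in this assay. The expected change is a number 0.17 log units higher from compound 3 to compound 4 (within the scatter) in this estimate. For compound 4 the estimated value is 9.45, with a likely range from 9.2 to 9.7.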

Compound 4, acid dissociation constant: 9.47
Beside the measured number, compound 4's estimate is 0.02 log units below it; the measured number falls inside the stated range.
By their numbers in this assay, from the lowest: compounds 2, 3, 1 and 4 (each within the scatter of the next).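

In this assay, the plain benzyl of compound 4 shows that the two methyl groups of compound 1 leave no readable mark, with no change at the digits printed from compound 1 to compound 4 (within the scatter) as the step between them. Benzyl in place of 4-fluorophenoxy gives a number 0.19 log units higher from compound 3 to compound 4 (within the scatter) and benzyl in place of 3-methoxyphenoxy gives a number 0.19 log units higher from compound 2 to compound 4 (within the scatter) at this aromatic carbon, so neither exchange separates the benzyl and phenoxy groups beyond the scatter. Nothing available explains these numbers.

From the compounds shown here alone, every group compared here at this position carries a six-membered aromatic ring of carbon only, so the effect of a much smaller group, such as a nitrile, remains open. A carboxylic acid or an amine at the same carbon also remains untested in the compounds shown.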